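A few compounds are considered here, and "the series" means these few. Any claim that something is new, unique, unknown or untested is made for them only; others in the source may bear on it.

Compounds measured in a functional assay on A-375 cells (Homo sapiens) for antiproliferative activity; a higher number here means a weaker inhibitor, a lower number a stronger inhibitor:

- compound 1 `O=C(Nc1ccc(-c2cscn2)cc1)C1CCCN(Cc2ccc(F)cc2)C1`: 2250 nM
- compound 2 `O=C(Nc1ccc(-c2cscn2)cc1)C1CCCN(Cc2cccc(C(F)(F)F)c2)C1`: this is a limit of the assay, > 20000 nM
- compound 3 `O=C(Nc1ccc(-c2cccnc2)cc1)C1CCCN(Cc2ccc(F)c(F)c2)C1`: 610 nM

Of the two values that are numbers, compound 3 gives the lowest; compound 1 stands clearly higher, by a gap beyond the usual scatter. Compound 2 yields no number at all, only (the limit of > 20000 nM in this assay, at which 1 of the 3 values shown sits).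

For the measured compounds named here, the single measured step, an at least 8.8-fold higher number from compound 1 to compound 2 (0.94 log units; beyond the scatter), concerns the group carried on the saturated chain carbon bound to the amine nitrogen in the ring, a different part of the shared core from the change considered here.

Compound 4 `O=C(Nc1ccc(-c2cc[nH]c2)cc1)C1CCCN(Cc2ccc(F)c(F)c2)C1` differs from compound 3 by 1H-pyrrol-3-yl in place of pyridin-3-yl on an aromatic carbon. Going by the values given here, no measured step touches this position, so the data give no direction for the change; the expectation therefore rests on compound 3 alone and is wide. Compound 4 is expected to give about 1000 nM, within a range from 250 nM to 5000 nM. The step of a 1.6-fold higher number from compound 3 to compound 4 (0.21 log units; within the scatter) is expected to be small, likely within the scatter.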

Compound 4, half-maximal inhibitory concentration: 1420 nM
Compound 4: the middle estimate sits 1.4-fold (0.15 log units) below what was measured; the measured number falls inside the stated range.
By their numbers in this assay, from the lowest: compound 3; then compounds 4 and 1 (each within the scatter of the next). At a limit, above all of these: compound 2.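

In this assay, for the compounds shown here, 1H-pyrrol-3-yl in place of pyridin-3-yl gives a 2.3-fold higher number from compound 3 to compound 4 (0.37 log units; beyond the scatter), the first measured reading at this position, on an aromatic carbon para to a large group. The step is modest, but it shows that the choice of aromatic ring here does register in this assay, with pyridin-3-yl the better of the two. The swap alters two things at once, from a six-membered to a five-membered aromatic ring and from a hydrogen-bond acceptor to a hydrogen-bond donor, and no measured property here accounts for the direction of the step.

Which of those two differences drives the step stays open. So does the effect of a plain phenyl ring, an amine or a carboxylic acid on this same carbon.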